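Carbonyl substituent swap: compound 1 to compound 4

The source may report more compounds than this note shows. Statements on the series, on what has been measured and on what is new or still open speak of the compounds shown alone.

Compound 1 `Cc1nc(S(C)(=O)=O)ccc1Oc1ncnc(OC2CCN(C(=O)O[C@H](C)CF)CC2)c1F` has the highest number of the three measured compounds in a functional assay on isolated protein for inhibition of Glucose-dependent insulinotropic receptor (Homo sapiens), read by HTRF and cAMP accumulation; a lower number here means that less compound is needed, a higher number that more compound is needed for the effect; in this assay compound 1 gives 196 nM. Compound 2 `CCC1(OC(=O)N2CCC(Oc3ncnc(Oc4ccc(S(C)(=O)=O)nc4C)c3F)CC2)CC1` gives 22 nM, and compound 3 `Cc1nc(S(C)(=O)=O)ccc1Oc1ncnc(OC2CCN(C(=O)SC(C)(C)C)CC2)c1F` gives 4.83 nM. Both steps away from compound 1 lie beyond the scatter: an 8.9-fold lower number from compound 1 to compound 2 (0.95 log units; beyond the scatter) and a 41-fold lower number from compound 1 to compound 3 (1.61 log units; beyond the scatter). Between the two lower values, a 4.6-fold lower number from compound 2 to compound 3 (0.66 log units; beyond the scatter).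

Compound 4 `Cc1nc(S(C)(=O)=O)ccc1Oc1ncnc(OC2CCN(C(=O)C3CCCC3)CC2)c1F` differs from compound 1 in a single place: a group of 5 heavy atoms (5 carbon; one five-membered non-aromatic ring of carbon only) in place of a group of 5 heavy atoms (3 carbon, 1 oxygen, 1 fluorine; no ring), on a carbonyl carbon. The two measured steps that bear on it are those that also exchange the group on the carbonyl carbon of compound 1, namely an 8.9-fold lower number from compound 1 to compound 2 (0.95 log units; beyond the scatter) and a 41-fold lower number from compound 1 to compound 3 (1.61 log units; beyond the scatter); both move the number downward by a modest to large amount. For the measured compounds named here, no measured pair here holds a cyclopentyl group, so the size of the effect for compound 4 cannot be read directly from an existing step, but the direction is consistent across the pairs seen.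

For compound 4, a lower number than that of compound 1 is therefore expected, with the step estimated as a 6.5-fold lower number from compound 1 to compound 4 (0.82 log units; beyond the scatter). Compound 4 is estimated at 30 nM, within a range from 8 nM to 120 nM.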

Compound 4, half-maximal effective concentration: 72.8 nM
Compound 4: middle estimate off by 2.4-fold (0.39 log units), on the low side, within the range that was stated.
By their numbers in this assay, from the lowest: compound 3; then compound 2; then compound 4; then compound 1.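

In this assay, the cyclopentyl group, which carries no oxygen or sulfur, still gives a lower number than the group it replaces on the carbonyl carbon (a 2.7-fold lower number from compound 1 to compound 4 (0.43 log units; beyond the scatter)), so a drop beyond the scatter from compound 1 does not depend on either atom in the incoming group. Compound 4 nevertheless stands above both of the other replacements (a 3.3-fold higher number from compound 2 to compound 4 (0.52 log units; beyond the scatter); a 15-fold higher number from compound 3 to compound 4 (1.18 log units; beyond the scatter)), which puts the all-carbon ring third of the four at this position. The (tert-butyl)sulfanyl group of compound 3 holds the lowest number, and its steps to all three other compounds lie beyond the scatter.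

The data in hand offer no explanation for this order.

Compound 3 and compound 4 differ in both the attached atom and the carbon group, so the compounds shown cannot separate the contribution of the sulfur from that of the tert-butyl group. A tert-butyl group or a cyclopentyloxy group on the same carbonyl carbon would address that question, while an amine there, giving a urea, remains an open case.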